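Swapping carboxy for isopropyl in a small series

The compounds below may be only part of what the source reports. "The series", "measured", "known", "first", "only" and "open" are said of these compounds alone.

In a functional assay on KB 3-1 cells (Homo sapiens) for cytotoxicity, read by MTT assay, with a stated time of 72 h (on this read-out lower numbers stand for stronger inhibition and higher numbers for weaker inhibition), compound 3 (`O=C1Nc2ccccc2/C1=N/NC(=S)Nc1ccc(C(=O)O)cc1`) gives > 50000 nM as its reading, which is a limit of the assay and not a number. In this assay two close relatives returned real numbers, with compound 1 (`O=C1Nc2ccccc2/C1=N/NC(=S)Nc1ccc(Cl)cc1`) at 13400 nM and compound 2 (`CN(C)c1ccc(NC(=S)N/N=C2\C(=O)Nc3ccccc32)cc1`) at 6950 nM as their readings.

Compound 4 (`CC(C)c1ccc(NC(=S)N/N=C2\C(=O)Nc3ccccc32)cc1`) differs from compound 3 in one place (isopropyl in place of carboxy on an aromatic carbon), with isopropyl in place of carboxy on an aromatic carbon. Within the data shown here, three measured steps bear on this change. Trading chloro for dimethylamino changed little (a 1.9-fold lower number from compound 1 to compound 2 (0.29 log units; within the scatter)). Putting carboxy in place of chloro raised the number (an at least 3.7-fold higher number from compound 1 to compound 3 (0.57 log units; beyond the scatter)), and putting it in place of dimethylamino raised it too (an at least 7.1-fold higher number from compound 2 to compound 3 (0.85 log units; beyond the scatter)).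

Isopropyl itself is untested in this small set, but compound 4 no longer carries the carboxy, so a clear step to a lower number is expected in this assay, roughly the reverse of the rise seen with compound 3 (an at least 7.1-fold higher number from compound 2 to compound 3 (0.85 log units; beyond the scatter)). The expected change is a drop (an at least 6.2-fold lower number from compound 3 to compound 4 (0.79 log units; beyond the scatter)). Compound 4 is estimated at 8000 nM as a middle value, with a likely range from 3000 nM to 20000 nM around it.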

Compound 4, half-maximal inhibitory concentration: 9110 nM
Estimate against measurement, compound 4: 1.1-fold (0.06 log units) below; the range from low to high includes it.
By their numbers in this assay, from the lowest: compounds 2, 4 and 1 (each within the scatter of the next). At a limit, above all of these: compound 3.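

In this assay, isopropyl in place of carboxy gives an at least 5.4-fold lower number from compound 3 to compound 4 (0.73 log units; beyond the scatter), so a third group at this place, para to a large group, returns a real number, and one made of carbon only. The new group also falls in with the two earlier ones: a 1.3-fold higher number from compound 2 to compound 4 (0.12 log units; within the scatter) and a 1.5-fold lower number from compound 1 to compound 4 (0.17 log units; within the scatter) both lie within the scatter, so isopropyl, dimethylamino and chloro cannot be told apart here, and among the four groups shown only carboxy stands apart. The true size of the step from carboxy stays unknown, since the reading of compound 3 is a limit and not a number: the limit of > 50000 nM in this assay, at which 1 of the 4 values shown sits.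

From the compounds shown here alone, whether carboxy itself sets compound 3 apart, or whether a close relative such as a methyl ester or a primary amide at the same place would read the same way, remains open. Also open, going by these compounds, is how a bare hydrogen or a longer chain such as hexyl would read here, and so whether the level readings of compounds 1, 2 and 4 extend to other groups.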